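A few compounds are considered here, and "the series" means these few. Any claim that something is new, unique, unknown or untested is made for them only; others in the source may bear on it.

In a functional assay on G-361 cells (Homo sapiens) for cytotoxicity, read by fluorescence, with a stated time of 72 h (on this read-out lower numbers stand for stronger inhibition and higher numbers for weaker inhibition), compound 1 `CC(C)c1n[nH]c2c(NCc3ccc(-c4ccccn4)cc3)nc(NCCN)nc12` gives 230 nM, compound 3 `CC(C)c1n[nH]c2c(NCc3ccc(-c4ccccn4)cc3)nc(N3CCNCC3)nc12` gives 64 nM, and compound 2 `CC(C)c1n[nH]c2c(NCc3ccc(-c4ccccn4)cc3)nc(NCC(N)CO)nc12` gives 1020 nM, the highest number of the three. Compound 4 `CC(C)c1n[nH]c2c(NCc3ccc(-c4ccccn4)cc3)nc(NCc3ccc(-c4ccccn4)cc3)nc12` departs from compound 2 as follows: 4-(pyridin-2-yl)phenyl in place of 1-amino-2-hydroxyethyl on a saturated chain carbon bound to a nitrogen on an aromatic ring. All three measured steps alter this same substituent: a 4.4-fold higher number from compound 1 to compound 2 (0.65 log units; beyond the scatter) and a 3.6-fold lower number from compound 1 to compound 3 (0.56 log units; beyond the scatter) are modest, while a 16-fold lower number from compound 2 to compound 3 (1.20 log units; beyond the scatter) is large. They show that the read-out responds to this substituent, but none removes the amino group or brings in 4-(pyridin-2-yl)phenyl, so their direction does not carry over directly. The expected change is modest and towards weaker inhibition, estimated as a 2.5-fold higher number from compound 2 to compound 4 (0.39 log units; beyond the scatter). Compound 4 is estimated at 2500 nM, with an expected range of 600 nM to 10000 nM.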

Compound 4, half-maximal inhibitory concentration: 3610 nM
Estimate against measurement, compound 4: 1.4-fold (0.16 log units) below; the range from low to high includes it.
By their numbers in this assay, from the lowest: compound 3; then compound 1; then compound 2; then compound 4.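

Putting 4-(pyridin-2-yl)phenyl on this saturated chain carbon gives a 3.5-fold higher number from compound 2 to compound 4 (0.55 log units; beyond the scatter) and a 16-fold higher number from compound 1 to compound 4 (1.20 log units; beyond the scatter), so a large group with two aromatic rings and no amino group does not restore the number seen with aminomethyl. Across compound 1, compound 2 and compound 4, the number rises from aminomethyl through 1-amino-2-hydroxyethyl to 4-(pyridin-2-yl)phenyl.

A 4-(aminomethyl)phenyl group or a plain phenyl group at this place would help separate the amino group's loss from the gain of aromatic rings. No evidence at hand explains the rise.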